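Aryl swap on the ring nitrogen at two linker lengths

A few compounds are considered here, and "the series" means these few. Any claim that something is new, unique, unknown or untested is made for them only; others in the source may bear on it.

Measured so far:
compound 1 `O=C(CCN1C(=O)CSc2ccccc21)N1CCN(c2ccc([N+](=O)[O-])cc2)CC1`; in a functional assay on IMR-32 cells (Homo sapiens) for inhibition, read by sulforhodamine B assay, with a stated time of 48 h (on this read-out higher numbers stand for weaker inhibition of growth and lower numbers for stronger inhibition of growth), compound 1 gives 340 nM.
compound 2 `COc1ccccc1N1CCN(C(=O)CCN2C(=O)CSc3ccccc32)CC1`; in this assay compound 2 reaches only a limit of the assay, > 100000 nM.
compound 3 `O=C(CCN1C(=O)CSc2ccccc21)NCCCN1CCN(c2ccc([N+](=O)[O-])cc2)CC1`; in this assay compound 3 gives 460 nM.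

Compound 4 `COc1ccccc1N1CCN(CCCNC(=O)CCN2C(=O)CSc3ccccc32)CC1` is not yet measured in this assay. The difference between the core of compound 1 and the core of compound 3 is not broken down here; the two values sit within the scatter of each other. The change from compound 1 to compound 2 is 2-methoxyphenyl in place of 4-nitrophenyl on an amine nitrogen in a ring, and in this assay it gives an at least 290-fold higher number from compound 1 to compound 2 (2.46 log units; beyond the scatter). That end point is the limit of > 100000 nM in this assay, at which 1 of the 3 values shown sits, so the true size of the step is not known. The change from compound 3 to compound 4 is 2-methoxyphenyl in place of 4-nitrophenyl on an amine nitrogen in a ring, the same change at the same place. In this assay the step from compound 3 to compound 4 is expected to be a 220-fold higher number from compound 3 to compound 4 (2.34 log units; beyond the scatter) because the same change gives an at least 290-fold higher number from compound 1 to compound 2 (2.46 log units; beyond the scatter). Compound 4 is therefore expected at 100000 nM, within 20000 nM to 400000 nM, and most likely the assay will again report only a limit.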

Compound 4, concentration for 50% growth inhibition: > 100000 nM
Compound 4: a limit, no number (the forecaster's own chance of this, stated with the estimate: 70%); the middle value lies on the limit itself.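

In this assay, 2-methoxyphenyl in place of 4-nitrophenyl on an amine nitrogen in a ring gives an at least 210-fold higher number from compound 3 to compound 4 (2.33 log units; beyond the scatter), so on both cores shown the change goes the same way and the step is large: the same change on two cores in this assay, an at least 290-fold higher number (2.46 log units; beyond the scatter) from compound 1 to compound 2 and an at least 210-fold higher number (2.33 log units; beyond the scatter) from compound 3 to compound 4; the limit leaves it open whether they differ

Compound 4 gives > 100000 nM, a limit of the assay and not a number. Whether the step has the same size on the two cores stays unknown, since the end points of both steps are limits, and two cores say nothing about others: the limit of > 100000 nM in this assay, at which 2 of the 4 values shown sit.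

Among the compounds shown here, still open is which part of the swap accounts for the step, as only two aryl groups appear on this nitrogen; an unsubstituted phenyl, 4-methoxyphenyl or 2-nitrophenyl would separate the identity of the group from its place on the ring. Also open is how the 4-nitrophenyl series behaves with a longer chain than those shown.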